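Replacing the furan of compound 1 with 4-methoxyphenyl

The source may hold more compounds than are shown below. What is called first, only, known or untested is meant among the compounds shown, and "the series" means these compounds.

The values below come from a functional assay on KB cells (Homo sapiens) for inhibition, with a stated time of 72 h; on this read-out higher numbers stand for weaker inhibition and lower numbers for stronger inhibition.

Compound 1 `COc1ccc(S(=O)(=O)N2CCc3cccc(-c4ccco4)c32)cc1` gives 82 nM
Compound 2 `COc1ccc(S(=O)(=O)N2CCc3cccc(-c4ccc(F)c(F)c4)c32)cc1` gives 45 nM

Among the compounds with values here, compound 1 has only one measured neighbour, and the two sit within the scatter of each other, the step being a 1.8-fold lower number from compound 1 to compound 2 (0.26 log units; within the scatter). Compound 3 `COc1ccc(-c2cccc3c2N(S(=O)(=O)c2ccc(OC)cc2)CC3)cc1` has not yet been measured. It keeps the core of compound 1 and differs in one place: 4-methoxyphenyl in place of furan-2-yl on an aromatic carbon. Put simply, 4-methoxyphenyl stands in place of furan-2-yl on an aromatic carbon.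

Within the data shown here, one measured step bears on this change. Compound 2 also gives up furan-2-yl for a six-membered aromatic ring of carbon only, there 3,4-difluorophenyl, and that swap produced no change beyond the scatter, with compound 2 at 45 nM. Among the measured compounds shown here, no measured compound carries 4-methoxyphenyl, so this single step is a thin guide. In this assay no step beyond the scatter is expected, with only a slight lean towards a lower number. The expected step is a 1.5-fold lower number from compound 1 to compound 3 (0.17 log units; within the scatter). Compound 3 is estimated at 55 nM, with an expected range from 20 nM to 150 nM.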

Compound 3, half-maximal inhibitory concentration: 337 nM
Compound 3: middle estimate off by 6.1-fold (0.79 log units), on the low side; measured number outside the range, above it.
By their numbers in this assay, from the lowest: compounds 2 and 1 (each within the scatter of the next); then compound 3.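

Read in this assay the position on the aromatic carbon of the shared core proves not to be indifferent to what it carries: 4-methoxyphenyl in place of furan-2-yl gives a 4.1-fold higher number from compound 1 to compound 3 (0.61 log units; beyond the scatter) and so goes beyond the scatter, which the earlier step between compound 1 and compound 2 did not do. Two rings of the same kind also part here: 4-methoxyphenyl in place of 3,4-difluorophenyl gives a 7.5-fold higher number from compound 2 to compound 3 (0.87 log units; beyond the scatter) and so, at this place, a six-membered aromatic ring of carbon only does not by itself hold the number where compound 2 has it. No measurement given here speaks to why the number rises with this change.

The compounds shown leave open which part of 4-methoxyphenyl goes with the higher number, a question that a plain phenyl or a 4-fluorophenyl at this place could help to separate. On these data alone, whether an amine or a carboxylic acid on that ring would move the number further also remains open.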